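The compounds below may be only part of what the source reports. "The series", "measured", "known", "first", "only" and "open" are said of these compounds alone.

Three ureas built on a shared chloro-trifluoromethylphenyl urea unit have been measured in a functional assay on A549 cells (Homo sapiens) for inhibition, read by sulforhodamine B assay, with a stated time of 48 h; a higher number here means a weaker inhibitor, a lower number a stronger inhibitor. Compound 1 `O=C(Nc1ccc2c(c1)CCN2c1ccc(C(=O)NO)cc1)Nc1ccc(Cl)c(C(F)(F)F)c1` gives 3400 nM. Compound 2 `O=C(Nc1ccc(C(=O)NO)cc1)Nc1ccc(Cl)c(C(F)(F)F)c1` gives 7200 nM, and compound 3 `O=C(CCCCCCC(=O)Nc1ccc(NC(=O)Nc2ccc(Cl)c(C(F)(F)F)c2)cc1)NO` gives 9500 nM. Among these three numbers compound 2 stands second highest: its nearest neighbour is compound 3, whose value lies within the usual scatter of compound 2, while compound 1 lies furthest away, with a lower number that is beyond the scatter.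

The next compound, compound 4 `O=C(/C=C/c1ccc(NC(=O)Nc2ccc(Cl)c(C(F)(F)F)c2)cc1)NO`, is derived from compound 2 by a single change: 2-(hydroxycarbamoyl)ethenyl in place of hydroxycarbamoyl on an aromatic carbon. For the measured compounds named here, no pair of measured compounds shows this exact step, so its size can only be estimated. Compound 3 suggests that a longer link between the urea-bearing ring and the hydroxamic acid is tolerated in this assay, since compound 3 gives 9500 nM. Compound 4 is therefore expected to show a modest step toward a lower number, a 2.4-fold lower number from compound 2 to compound 4 (0.38 log units; beyond the scatter), with the direction uncertain. The estimate for compound 4 in this assay is 3000 nM, within a range from 800 nM to 12000 nM.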

Compound 4, half-maximal inhibitory concentration: 3400 nM
The estimate for compound 4 lay 1.1-fold (0.05 log units) below the measured number; the range from low to high includes it.
By their numbers in this assay, from the lowest: compounds 1 and 4 (each within the scatter of the next); then compounds 2 and 3 (each within the scatter of the next).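

For the compounds shown here, on an aromatic carbon para to a large group, 2-(hydroxycarbamoyl)ethenyl in place of hydroxycarbamoyl gives the first step that can be read directly: this assay shows a 2.1-fold lower number from compound 2 to compound 4 (0.33 log units; beyond the scatter), a modest change but one beyond the scatter. At this position, therefore, the larger group with its added carbons and second double bond is accepted without a rise in the number, and the hydroxamic acid need not sit directly on the ring. No measurement at hand accounts for this step.

The compounds shown leave open whether the double bond or the added carbons carry the step; a saturated 2-(hydroxycarbamoyl)ethyl group would separate the two. They also leave open how a carboxylic acid would fare at this position in place of the hydroxamic acid.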